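The source may report more compounds than this note shows. Statements on the series, on what has been measured and on what is new or still open speak of the compounds shown alone.

In a functional assay on SW480 cells (Homo sapiens) for antiproliferative activity, read by MTT assay, with a stated time of 48 h (a lower number here means a stronger inhibitor, a higher number a weaker inhibitor), the measured compounds read:

Compound 1 `CCCC(CCO)n1cnc2c(Cl)ncnc21`: > 50000 nM
Compound 2 `CCCCCCC(CCO)n1cnc2c(Cl)ncnc21`: 16700 nM
Compound 3 `CCCCCCC(CCO)n1cnc2c(Cl)nc(Cl)nc21`: 12400 nM

The entry for compound 1, > 50000 nM, is a limit of the assay and not a number. That leaves two true numbers, and compound 2 at 16700 nM sits level with its nearest neighbour, compound 3 at 12400 nM. The gap between them is a 1.3-fold lower number from compound 2 to compound 3 (0.13 log units; within the scatter).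

Compound 4 `CCCCCCC(CCO)n1cnc2c(N(C)C)ncnc21` keeps the chain of compound 2 and carries dimethylamino in place of chloro on an aromatic carbon. Within the data shown here, no measured step makes this exchange, so the evidence is indirect. Among the measured compounds shown here, the only measured change on an aromatic carbon is a 1.3-fold lower number from compound 2 to compound 3 (0.13 log units; within the scatter), and it adds a chloro at another place. The chain change, an at least 2.9-fold lower number from compound 1 to compound 2 (0.47 log units; beyond the scatter), lies away from the exchanged group and says little about it. Every measured compound keeps the chloro that compound 4 loses, so the direction is a tentative expectation, and a modest move towards a higher number is the cautious guess. The expected change is a 1.4-fold higher number from compound 2 to compound 4 (0.16 log units; within the scatter). For compound 4 the estimated value is 24000 nM, with an expected range from 10000 nM to 50000 nM.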

Compound 4, half-maximal inhibitory concentration: > 50000 nM
Compound 4: only a limit was reported; the forecaster's own chance of this, stated with the estimate: 35%; at least 2.0-fold (0.31 log units) between middle value and limit.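

In this assay, the replacement of chloro by dimethylamino gives the only step shown at this position, on an aromatic carbon next to the ring nitrogen, and it reads an at least 2.9-fold higher number from compound 2 to compound 4 (0.47 log units; beyond the scatter). Compound 4 gives > 50000 nM, which is a limit of the assay and not a number. The earlier compounds all kept this chloro, so this is the first sign that the position is not indifferent to exchange, although the step fixes only a lower bound on the change and not its size, and the same limit sets the ceiling of what can be read here: the limit of > 50000 nM in this assay, at which 2 of the 4 values shown sit.

The compounds shown leave open whether the step reflects the departure of chloro or the arrival of dimethylamino, a question that a simple amine, a methoxy group or a plain hydrogen on the same carbon could help to separate. They also leave open whether the same exchange would read alike in the presence of the second chloro of compound 3.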